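Extending the Ester Alkyl Chain on a Shared Core

This account rests on a few compounds, and the source may have more. Where it says the series, first, only, none or still open, it means among the compounds named here.

Compound 1 `CCOC(=O)CCC(=O)N1CCN(CCCOc2cc3c(Nc4ccc(F)c(Cl)c4)ncnc3cc2OC)CC1` gives 70% in a functional assay on A549 cells (Homo sapiens) for cytotoxicity, read by MTT assay, with a stated time of 24 h, tested at 20 uM; on this read-out lower numbers stand for a stronger effect and higher numbers for a weaker effect at the one concentration tested. Compound 2 `CCCOC(=O)CCC(=O)N1CCN(CCCOc2cc3c(Nc4ccc(F)c(Cl)c4)ncnc3cc2OC)CC1` gives 87% in this assay, and compound 3 `CCCCCCCCCCCOC(=O)CCC(=O)N1CCN(CCCOc2cc3c(Nc4ccc(F)c(Cl)c4)ncnc3cc2OC)CC1` gives 85.2% in this assay. Compound 2 arises from compound 1 by methyl in place of hydrogen on a saturated chain carbon, two bonds along the chain from an oxygen next to a carbonyl group, a change that brought a number 17 percentage points higher from compound 1 to compound 2 (beyond the scatter). Compound 3 differs from compound 1 by nonyl in place of hydrogen on a saturated chain carbon, two bonds along the chain from an oxygen next to a carbonyl group, with a number 15.2 percentage points higher from compound 1 to compound 3 (beyond the scatter). The further lengthening gave a number 1.8 percentage points lower from compound 2 to compound 3 (within the scatter). Compound 4 `CCCCCCCCCCCCOC(=O)CCC(=O)N1CCN(CCCOc2cc3c(Nc4ccc(F)c(Cl)c4)ncnc3cc2OC)CC1` is not yet measured; it arises from compound 3 by methyl in place of hydrogen on a saturated chain carbon, ten or more bonds along the chain from an oxygen next to a carbonyl group, the same kind of group entering as in the change from compound 1 to compound 2. For compound 4 the expected step is a number 0.2 percentage points lower from compound 3 to compound 4 (within the scatter), because a number 1.8 percentage points lower from compound 2 to compound 3 (within the scatter) lies within the scatter. Compound 4 is therefore estimated at 85%, between 75% and 95%.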

Compound 4, a percentage reported as activity, at one concentration (the size of the read-out at that concentration, not a potency): 86.8%
Compound 4: the middle estimate sits 1.8 percentage points below what was measured; measured number inside the range.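

In this assay, methyl in place of hydrogen gave a number 1.6 percentage points higher from compound 3 to compound 4 (within the scatter), so this change did not carry over at the same size from one core to the other: the same change on two cores in this assay, a number 17 percentage points higher (beyond the scatter) from compound 1 to compound 2 and a number 1.6 percentage points higher (within the scatter) from compound 3 to compound 4, 15.4 percentage points apart, beyond the scatter of two such steps. Nonyl in place of hydrogen gave a number 0.2 percentage points lower from compound 2 to compound 4 (within the scatter) and decyl in place of hydrogen gave a number 16.8 percentage points higher from compound 1 to compound 4 (beyond the scatter), and the nonyl change also failed to carry over: the same change on two cores in this assay, a number 15.2 percentage points higher (beyond the scatter) from compound 1 to compound 3 and a number 0.2 percentage points lower (within the scatter) from compound 2 to compound 4, 15.4 percentage points apart, beyond the scatter of two such steps. Among these four compounds, only the steps starting from compound 1 lie beyond the scatter, but this does not show why, and the paired changes also sit at different places along the chain.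

The compounds shown leave open how a free carboxylic acid or a methyl ester in place of these esters would read in this assay. On these data alone, a branched chain or a chain ending in an amine also remains open.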